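The source may report more compounds than this note shows. Statements on the series, on what has been measured and on what is new or still open speak of the compounds shown alone.

Measured so far:
- Compound 1 `COc1cc(C2C(C#N)=C(N)Oc3cc(Br)ccc32)cc(Br)c1OC` — 140000000 nM
- Compound 2 `CCNc1ccc2c(c1)OC(N)=C(C#N)C2c1cc(OC)cc(OC)c1` — 61700000 nM
- Compound 3 `N#CC1=C(N)Oc2c(ccc(N)c2N)C1c1cccc(C#N)c1` — 390000000 nM

In a functional assay on T47D cells (Homo sapiens) for activation (a lower number here means that less compound is needed, a higher number that more compound is needed for the effect), compound 3 gives the highest of the three numbers. Compound 1 comes closest to it, and compound 2 lies furthest away, both differences reaching beyond the scatter of this assay.

Compound 4 `N#CC1=C(N)Oc2c(ccc(N)c2N)C1c1cccc(Br)c1` has not yet been measured. It differs from compound 3 in one place: bromo in place of cyano on an aromatic carbon. Within the data shown here, no pair of measured compounds shows this exchange on its own, so the size of the step is open. Compound 1, which also carries bromo on its pendant aromatic ring, gives 140000000 nM, which points to a modest move toward a lower number at most. Compound 4 is therefore expected to show a small step from compound 3, a 1.6-fold lower number from compound 3 to compound 4 (0.19 log units; within the scatter), and its estimated value is 250000000 nM with a range from 80000000 nM to 800000000 nM.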

Compound 4, half-maximal effective concentration: 150000000 nM
Compound 4: the middle estimate sits 1.7-fold (0.22 log units) above what was measured, and the stated range covers the measured number.
By their numbers in this assay, from the lowest: compound 2; then compounds 1 and 4 (each within the scatter of the next); then compound 3.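

In this assay the exchange of cyano for bromo on this aromatic carbon gives a 2.6-fold lower number from compound 3 to compound 4 (0.41 log units; beyond the scatter) and so supplies the only single-place step among these compounds, modest but beyond the scatter. The position therefore responds to this change, with bromo giving the lower number. Nothing available here offers a reason for the step. As far as these compounds go, whether chloro or a carboxylic acid on the same carbon would move the number further remains open. So does whether this exchange would give a similar step on the core of compound 1.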